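Carboxy in Place of Hydroxymethyl: Expectation for Compound 4

The source may report more compounds than this note shows. Statements on the series, on what has been measured and on what is new or still open speak of the compounds shown alone.

Compound 1 `O=C(NO)c1ccc(-c2cn([C@H]3C[C@@H](CO)N(Cc4ccccc4)C3)nn2)cc1` gives, in an assay on Sf9 cells for inhibition of histone deacetylase 11 (Homo sapiens), read by fluorescence, tested at 0.5 uM (a higher number here means more inhibition at the concentration tested (going by the name of the read-out), a lower number less inhibition), the limit < 10%.
Compound 2 `O=C(NO)c1cccc(-c2cn([C@@H]3C[C@@H](CO)N(Cc4ccccc4)C3)nn2)c1` gives in this assay the limit < 10%.
Compound 3 `O=C(/C=C/c1cn([C@@H]2C[C@H](CO)N(CCCc3ccccc3)C2)nn1)NO` gives in this assay 12%.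

Compound 1 stands at the limit of < 10% in this assay, at which 2 of the 3 values shown sit, so for it only a limit is known, not a number, and the same holds for compound 2. For the measured compounds named here, compound 3 is the one measured value here, and it lies within the usual scatter of that limit.

Compound 4 `O=C(NO)c1ccc(-c2cn([C@H]3C[C@@H](C(=O)O)N(Cc4ccccc4)C3)nn2)cc1` differs from compound 1 by carboxy in place of hydroxymethyl on a saturated ring carbon. Going by the values given here, no step between measured compounds bears on this change. Without such a step, the expectation in this assay is a step of no size beyond the scatter, in no particular direction. Compound 4 is therefore expected to give about 7%, between 0% and 20%, a step that the limit leaves unreadable from compound 1 to compound 4 that is estimated to stay within the scatter.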

Compound 4, a percentage reported as inhibition, at one concentration (the size of the read-out at that concentration, not a potency): < 10%
Compound 4 gave a limit, no number; the forecaster's own chance of this, stated with the estimate: 65%; the middle value lies beyond the limit too.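

Compound 1 and compound 4 both stand at a limit rather than a number, so no step between them can be read: the limit of < 10% in this assay, at which 3 of the 4 values shown sit.

The compounds shown leave open whether carboxy in place of hydroxymethyl on a saturated ring carbon changes the result in this assay at all.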